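Thiourea Cytotoxicity in Hamster Kidney Cells: Toward Compound 4

This account rests on a few compounds, and the source may have more. Where it says the series, first, only, none or still open, it means among the compounds named here.

Measured in an ADME assay on BHK cells (Mesocricetus auratus) for cytotoxicity, read by MTT assay, with a stated time of 96 h; on this read-out lower numbers stand for higher toxicity in this test and higher numbers for lower toxicity in this test:
compound 1, `FC(F)(F)c1cccc(NC(=S)Nc2ccc(I)cc2)c1`, 9400 nM
compound 2, `Cc1ccc(NC(=S)Nc2cccc(C(F)(F)F)c2)cc1Cl`, 10000 nM
compound 3, `O=C(NC(=S)Nc1cccc(C(F)(F)F)c1)[C@H]1C[C@@H]2CC[C@H]1C2`, 9600 nM

Three thioureas carrying the shared core of compound 1 have been examined in this assay, and the three numbers sit close together. Compound 1 returns the numerically lowest figure of the set, but compound 3 lies nearest to it and compound 2 furthest, and both gaps fall within the usual scatter, so none of the three can be separated from the others on this read-out. A 4-iodophenyl, a 3-chloro-4-methylphenyl and a bicyclic carboxamide on the second nitrogen all leave the cytotoxic concentration essentially where it is.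

The account now moves from compound 1 to compound 4, `Fc1cccc(NC(=S)Nc2cccc(C(F)(F)F)c2)c1`, which has not yet been tested in this assay. The change is 3-fluorophenyl in place of 4-iodophenyl on an amide-type nitrogen.

Among the compounds with values here, no measured pair in the set differs by exactly this exchange, so the direction of the step cannot be read off a precedent. Since compound 1 at 9400 nM, compound 2 and compound 3 all converge on the same region despite quite different groups at this position, the expected step of a 1.1-fold higher number from compound 1 to compound 4 (0.03 log units; within the scatter) is none beyond the scatter. Compound 4 is accordingly estimated at 10000 nM, within a range of 5000 nM to 20000 nM.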

Compound 4, half-maximal cytotoxic concentration: 9400 nM
The estimate for compound 4 lay 1.1-fold (0.03 log units) above the measured number; measured number inside the range.
By their numbers in this assay, from the lowest: compounds 1, 4, 3 and 2 (each within the scatter of the next).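

In this assay, within the data shown here, 3-fluorophenyl in place of 4-iodophenyl on an amide-type nitrogen gives no change at the digits printed from compound 1 to compound 4 (within the scatter), the first direct comparison in this set of two compounds that differ in one place. The earlier compounds shown here could only suggest that this position tolerates change, whereas this pair shows that one halogen-bearing phenyl ring can replace another here with no change beyond the scatter, even though the halogen and its printed ring position change together in this single exchange. The data offer no independent measurement that would explain this result, and the separate contributions of the halogen and its ring position cannot be told apart from this pair.

The compounds shown leave open whether an amine or a carboxylic acid on this phenyl ring, or a longer alkyl chain in its place on the same nitrogen, would move the number beyond the scatter. The trifluoromethyl group is also present in all of them, so what a nitrile in its place would do remains an open question.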